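Two Aryl Sulfonamides at the Limit, a Naphthyl Next

This account rests on a few compounds, and the source may have more. Where it says the series, first, only, none or still open, it means among the compounds named here.

Of the compounds shown here, two sharing one core have been tested in a functional assay on KYSE-510 cells (Homo sapiens) for antiproliferative activity, read by crystal violet staining, with a stated time of 96 h; on this read-out higher numbers stand for weaker inhibition of growth and lower numbers for stronger inhibition of growth. Compound 1 `O=S(=O)(NC1=NCCN1C(=S)SN1CCn2c1nsc2=S)c1ccc(C(F)(F)F)cc1` carries a 4-(trifluoromethyl)phenyl group on the sulfonyl sulfur. In this assay compound 1 gives only the limit of the assay, >= 20000 nM, and no number. Compound 2 `O=S(=O)(NC1=NCCN1C(=S)SN1CCn2c1nsc2=S)c1ccc(Cl)cc1Cl` carries 2,4-dichlorophenyl in the same place. In this assay compound 2 likewise gives only the limit >= 20000 nM. For the measured compounds named here, the single step between them, a step that the two limits leave unreadable from compound 1 to compound 2, cannot be read, because of the limit of >= 20000 nM in this assay, at which 2 of the 2 values shown sit. Compound 3 `O=S(=O)(NC1=NCCN1C(=S)SN1CCn2c1nsc2=S)c1ccc2ccccc2c1` is the next member: naphthalen-2-yl in place of 2,4-dichlorophenyl on a sulfonyl sulfur. No measured step with a readable size bears on this change; the only step shown, from one aryl group to another, left its size unknown. What the two measurements do show is that both aryl groups sit at the same limit. For compound 3 the expectation is therefore a further limit or a value near it, with the estimated step of a number no higher from compound 2 to compound 3 (the limit leaves the size open) carrying little confidence. Compound 3 is expected to give about 20000 nM in this assay, within 5000 nM to 80000 nM.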

Compound 3, concentration for 50% growth inhibition: >= 20000 nM
Compound 3: only a limit was reported (the forecaster's own chance of this, stated with the estimate: 75%); the middle value sits exactly at the limit.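

In this assay, the steps linking compound 3 with compound 1 and compound 2 cannot be read, because all three compounds give a limit and not a number: the limit of >= 20000 nM in this assay, at which 3 of the 3 values shown sit.

The compounds shown leave open how strongly each inhibits growth, and whether any group on the sulfonyl sulfur of the shared core would give a readable value.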